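This account rests on a few compounds, and the source may have more. Where it says the series, first, only, none or still open, it means among the compounds named here.

Compound 3 `COc1ccccc1NC(=S)N1CCc2c(sc(NC(=O)c3ccccc3Cl)c2C(N)=O)C1` gives 35200 nM in a functional assay on MKN-74 cells (Homo sapiens) for antiproliferative activity, with a stated time of 24 h (a lower number here means a stronger inhibitor, a higher number a weaker inhibitor), the highest number among the three measured compounds: compound 2 `NC(=O)c1c(NC(=O)c2ccccc2Cl)sc2c1CCN(Cc1cc(Cl)cc(Cl)c1)C2` gives 23700 nM and compound 1 `NC(=O)c1c(NC(=O)c2ccccc2Cl)sc2c1CCN(Cc1c(Cl)cccc1Cl)C2` gives 4740 nM. The measured steps of a 5.0-fold higher number from compound 1 to compound 2 (0.70 log units; beyond the scatter), a 7.4-fold higher number from compound 1 to compound 3 (0.87 log units; beyond the scatter) and a 1.5-fold higher number from compound 2 to compound 3 (0.17 log units; within the scatter) all concern the group on the amine nitrogen in the ring. Compound 4 `COc1ccccc1NC(=S)N1CCc2c(sc(NC(=O)c3ccccc3I)c2C(N)=O)C1` differs from compound 3 elsewhere, carrying (iodo in place of chloro on an aromatic carbon). For the measured compounds named here, no measured step touches this position, so none of them bears directly on the change; the expected step is therefore one within the scatter, a 1.0-fold lower number from compound 3 to compound 4 (0.00 log units; within the scatter), with a wide range around it. Compound 4 is estimated at 35000 nM in this assay, somewhere between 12000 nM and 100000 nM.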

Compound 4, half-maximal inhibitory concentration: 41800 nM
Compound 4: middle estimate off by 1.2-fold (0.08 log units), on the low side, within the range that was stated.
By their numbers in this assay, from the lowest: compound 1; then compounds 2, 3 and 4 (each within the scatter of the next).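

Iodo in place of chloro on this aromatic carbon gives a 1.2-fold higher number from compound 3 to compound 4 (0.07 log units; within the scatter) in this assay, the first measured step at this position. With the group of compound 3 on the ring amine nitrogen, the two halogens therefore cannot be told apart in this assay, whereas changes to that nitrogen group include steps beyond the scatter. No supporting evidence bears on this result.

As far as these compounds go, whether the two halogens also read alike with the group of compound 1 stays open. So does the effect of an amine or a carboxylic acid at this carbon.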